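A few compounds are considered here, and "the series" means these few. Any claim that something is new, unique, unknown or untested is made for them only; others in the source may bear on it.

In a functional assay on RAW264.7 cells (Mus musculus) for inhibition, with stated times of 2 h and 24 h (a higher number here means a weaker inhibitor, a lower number a stronger inhibitor), compound 1 (`COc1cc(OC)cc([C@@H]2C(=O)c3cc(OC)cc(OC)c3[C@H]2c2ccc(F)cc2)c1`) gives 44800 nM as its measured value. Compound 2 (`COc1ccc([C@@H]2c3c(OC)cc(OC)cc3/C(=C/c3ccc(F)cc3)[C@H]2c2cc(OC)cc(OC)c2)cc1`) shows > 200000 nM which is a limit of the assay and not a number. Compound 3 (`COc1ccc([C@@H]2c3c(OC)cc(OC)cc3C(SCc3ccccc3)[C@H]2c2cc(OC)cc(OC)c2)cc1`) also shows > 200000 nM which is likewise only a limit. Compared with compound 3, compound 4 (`COc1ccc([C@@H]2c3c(OC)cc(OC)cc3C(C(O)c3ccc(F)cc3)[C@H]2c2cc(OC)cc(OC)c2)cc1`) carries (4-fluorophenyl)(hydroxy)methyl in place of benzylsulfanyl on a saturated ring carbon. For the measured compounds named here, no pair of measured compounds in this assay isolates this change, and only compound 1, at 44800 nM so far, gives a number. The estimated step (an at least 1.3-fold lower number from compound 3 to compound 4 (0.12 log units; that floor lies within the scatter)) is expected to be small and towards stronger inhibition. For compound 4 the estimated value is 150000 nM with an expected range from 50000 nM to 300000 nM in this measurement.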

Compound 4, half-maximal inhibitory concentration: > 200000 nM
Compound 4: no number, only a limit; the forecaster's own chance of this, stated with the estimate: 55%; middle value at least 1.3-fold (0.12 log units) away from the limit.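

No step can be read from compound 3 to compound 4, since both stand only at a limit: the limit of > 200000 nM in this assay, at which 3 of the 4 values shown sit.

The compounds shown leave open whether benzylsulfanyl or (4-fluorophenyl)(hydroxy)methyl on that saturated ring carbon gives the stronger inhibition.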